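This account rests on a few compounds, and the source may have more. Where it says the series, first, only, none or still open, it means among the compounds named here.

In a functional assay on the whole organism (Tail, strain ICR) with Mus musculus as the target, in the tail flick test, with a stated time of 60 min, at a dose of 25 umol/kg by the oral route (a lower number here means a weaker effect, a higher number a stronger effect of the compound at the dose given), three compounds of the series have been run. Compound 3 `CC(C)C[C@H](NC(=O)CN(c1ncnc2c1ncn2C1CCCCO1)C1CC1)C(=O)OCc1ccccc1` gives 34.2%. Compound 1 `NC(=O)C[C@H](NC(=O)CN(c1ncnc2c1ncn2C1CCCCO1)C1CC1)C(=O)OCc1ccccc1` gives 30.5%; the change from compound 3 to compound 1 is carbamoyl in place of isopropyl on a saturated chain carbon, two bonds along the chain from an amide-type nitrogen and a carbonyl carbon, and the resulting step is a number 3.7 percentage points lower from compound 3 to compound 1 (within the scatter). Compound 2 `CC(C)C[C@H](NC(=O)CN(c1nc(Cl)nc2[nH]cnc12)C1CC1)C(=O)OCc1ccccc1` gives 27.3%; its core differs from that of compound 3, but the difference between the two cores is not broken down here. The values of compound 2 and compound 3 lie within the scatter of each other, as do those of compound 2 and compound 1.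

Compound 4 `NC(=O)C[C@H](NC(=O)CN(c1nc(Cl)nc2[nH]cnc12)C1CC1)C(=O)OCc1ccccc1` remains to be measured. It stands to compound 2 as compound 1 stands to compound 3: the change is carbamoyl in place of isopropyl on a saturated chain carbon, two bonds along the chain from an amide-type nitrogen and a carbonyl carbon, the same change at a place described in the same words. Among the compounds with values here, the expectation rests on the single earlier step of a number 3.7 percentage points lower from compound 3 to compound 1 (within the scatter) of this change, which stayed within the scatter. The step is therefore expected to be a number 3.3 percentage points lower from compound 2 to compound 4 (within the scatter). Within the data shown here, with only one prior pair behind it, the spread is kept wide. Compound 4 is estimated at 24%, expected between 12% and 36%.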

Compound 4, a percentage reported as activity, at one dose (the size of the read-out at that dose, not a potency): 36.4%
Estimate against measurement, compound 4: 12.4 percentage points below, outside the stated range (above it).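

In this assay, carbamoyl in place of isopropyl on the core of compound 2 gives a number 9.1 percentage points higher from compound 2 to compound 4 (within the scatter). Set beside the earlier step on the other core, the result does not separate the two cores: the same change on two cores in this assay, a number 3.7 percentage points lower (within the scatter) from compound 3 to compound 1 and a number 9.1 percentage points higher (within the scatter) from compound 2 to compound 4, 12.8 percentage points apart, within the scatter of two such steps. The two steps therefore give no sign that the core alters what this change does, but they also do not show that the change carries over unaltered from one core to the other, or that it has any effect of its own on either core, as each core rests on a single pair at one dose and one time.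

The compounds shown hold only isopropyl and carbamoyl on a saturated chain carbon, two bonds along the chain from an amide-type nitrogen and a carbonyl carbon. Going by these compounds, it remains open whether an amine, a carboxylic acid or a longer chain at that place would give a step beyond the scatter in this assay on either core.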